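The source may report more compounds than this note shows. Statements on the series, on what has been measured and on what is new or still open speak of the compounds shown alone.

In a functional assay on DU-145 cells (Homo sapiens) for inhibition, read by WST assay, with a stated time of 3 days (a lower number here means a stronger inhibitor, a higher number a weaker inhibitor), compound 1 `Cn1ccnc1/C=C/C(=O)/C=C/c1coc2ccccc2c1=O` gives 4500 nM, and compound 2 `CCC(C)n1ccnc1/C=C/C(=O)/C=C/c1coc2ccccc2c1=O` gives 3300 nM. Among the measured compounds shown here, these are the only two numbers so far, and they lie within the usual scatter of each other, so compound 2 cannot be separated from compound 1. Compound 3 `CCC(CC)n1ccnc1/C=C/C(=O)/C=C/c1coc2ccccc2c1=O` differs from compound 2 at one place: methyl in place of hydrogen on a saturated chain carbon, two bonds along the chain from an aromatic nitrogen. This turns sec-butyl into pentan-3-yl. For the measured compounds named here, one measured step bears on this change, sec-butyl in place of methyl on an aromatic nitrogen, and it is a 1.4-fold lower number from compound 1 to compound 2 (0.13 log units; within the scatter). Since that step did not leave the scatter, no step beyond the scatter is expected in this assay here. The expected step is a 1.1-fold lower number from compound 2 to compound 3 (0.04 log units; within the scatter). For compound 3 the estimated value is 3000 nM, with an expected range of 1400 nM to 6500 nM.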

Compound 3, half-maximal inhibitory concentration: 5200 nM
For compound 3 the middle estimate is 1.7-fold (0.24 log units) below the measured one; measured number inside the range.
By their numbers in this assay, from the lowest: compounds 2, 1 and 3 (each within the scatter of the next).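

In this assay the added methyl on a saturated chain carbon, two bonds along the chain from an aromatic nitrogen, turns sec-butyl into pentan-3-yl and gives a 1.6-fold higher number from compound 2 to compound 3 (0.20 log units; within the scatter) and so stays within the scatter. Pentan-3-yl in place of methyl on that nitrogen gives a 1.2-fold higher number from compound 1 to compound 3 (0.06 log units; within the scatter) and also stays within the scatter, so methyl, sec-butyl and pentan-3-yl cannot be told apart here, and the extra carbon shows no direction of its own. Nothing available bears on why these steps are so small.

As far as these compounds go, it remains open whether any group at this place can move the number beyond the scatter, for instance a longer chain, a chain ending in an amine, or one carrying a carboxylic acid. Also open, from the compounds shown here alone, is whether these three groups would stay together in another cell line.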